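The source may hold more compounds than are shown below. What is called first, only, known or untested is meant among the compounds shown, and "the series" means these compounds.

Working notes on the series. Compound 1 `Cc1cc2c(c(N)nn2C)c(=O)[nH]1` and compound 2 `Cn1nc(N)c2c(=O)[nH]c(-c3ccccc3)cc21` share the same core and have been measured in an assay on isolated protein for inhibition of serine/threonine-protein kinase D2 (Homo sapiens), read by mobility shift assay, tested at 30 uM; a higher number here means more inhibition at the concentration tested (going by the name of the read-out), a lower number less inhibition. In this assay compound 1 gives 5% and compound 2 gives 14%. The single measured step, a number 9 percentage points higher from compound 1 to compound 2 (within the scatter), lies within the scatter of the method, so the two compounds cannot be separated on the numbers shown. Compound 2 stands with the higher of the two values, with compound 1 as its nearest and only neighbour; no ordering beyond the scatter is established.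

Compound 3 `Cn1nc(N)c2c(=O)[nH]c(-c3ccccn3)cc21` is next and differs from compound 2 by pyridin-2-yl in place of phenyl on an aromatic carbon. Going by the values given here, no measured step bears on this change; the only step available, from methyl to phenyl, was itself within the scatter. Starting from the value of compound 2, 14%, no step beyond the scatter is expected for compound 3 in this assay, so the step of no change at the digits printed from compound 2 to compound 3 (within the scatter) is the estimate. Compound 3 is accordingly expected to give about 14%, in the range 0% to 35%, in this assay.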

Compound 3, a percentage reported as inhibition, at one concentration (the size of the read-out at that concentration, not a potency): 17%
Beside the measured number, compound 3's estimate is 3 percentage points below it; the range from low to high includes it.
By their numbers in this assay, from the lowest: compounds 1, 2 and 3 (each within the scatter of the next, the first and the last beyond it).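

In this assay, pyridin-2-yl in place of phenyl on this aromatic carbon gives a number 3 percentage points higher from compound 2 to compound 3 (within the scatter), so the ring nitrogen and the hydrogen-bond acceptor that enter with pyridin-2-yl bring no change that can be separated from phenyl on these numbers. Pyridin-2-yl in place of methyl at the same position gives a number 12 percentage points higher from compound 1 to compound 3 (beyond the scatter), the first step in the series to pass the scatter, although only a modest one, and the phenyl-to-methyl comparison does not show the same. No supporting data are available to explain either step.

From the compounds shown here alone, whether an amine, a carboxylic acid or a longer alkyl chain at this position would give a larger step remains open. The compounds shown also leave open whether pyridin-3-yl or pyridin-4-yl would read differently from pyridin-2-yl.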